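Solubility of a pyridylmethylamine series: from compound 2 to compound 3

This account rests on a few compounds, and the source may have more. Where it says the series, first, only, none or still open, it means among the compounds named here.

The measured compounds and their values:
compound 1 `Cc1ccc(-c2cnn3c(NCc4ccccn4)cc(C)nc23)cc1`, < 5000 nM in a physicochemical assay for solubility, read by HPLC, using the shake flask method, measured as kinetic solubility, with a stated time of 2 h, at pH 7.4; a lower number here means a less soluble compound, a higher number a more soluble compound;
compound 2 `Cc1cc(NCc2ccccn2)n2ncc(-c3ccccc3F)c2n1`, 5000 nM in this assay.

Compound 1 carries a 4-methylphenyl group on the shared core, and its value in this assay is a limit of the assay, not a number. Going by the values given here, compound 2 has a 2-fluorophenyl in place of that 4-methylphenyl on an aromatic carbon, and the step of a number no lower from compound 1 to compound 2 (the limit leaves the size open) is the only measured step in this set. Compound 2 therefore stands on the only number shown; the one other value is a limit (the limit of < 5000 nM in this assay, at which 1 of the 2 values shown sits).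

Compound 3 `Cc1cc(NCc2ccccn2)n2ncc(-c3cc(F)c(F)c(F)c3)c2n1` differs from compound 2 by 3,4,5-trifluorophenyl in place of 2-fluorophenyl on an aromatic carbon. Among the compounds with values here, no measured step changes the fluorine count of this phenyl ring, so the single measured step, open in size as it is, gives no guide to the size of this one. Within the data shown here, with only the one number of compound 2 to rest on, compound 3 is expected to show the step of a 1.7-fold lower number from compound 2 to compound 3 (0.22 log units; within the scatter) in this assay. Compound 3 is estimated at 3000 nM, within the range 1000 nM to 8000 nM.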

Compound 3, solubility: < 5000 nM
Compound 3: only a limit was reported; the forecaster's own chance of this, stated with the estimate: 50%; the middle value is on the limit's open side.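

Compound 3 gives < 5000 nM in this assay, and this is a limit of the assay, not a number. Setting 3,4,5-trifluorophenyl in place of 2-fluorophenyl on this aromatic carbon gives a number no higher from compound 2 to compound 3 (the limit leaves the size open), so a change in the fluorine count of this phenyl ring, which no earlier step covered, now has a direction but no size. The step between compound 1 and compound 3 cannot be read, and compound 2 remains the only compound with a number, while the other two compounds rest on the same limit: the limit of < 5000 nM in this assay, at which 2 of the 3 values shown sit.

The compounds shown leave open how far compound 3 actually lies from compound 2, and whether 4-methylphenyl and 3,4,5-trifluorophenyl differ from each other at all in this assay. They also leave open whether a phenyl ring carrying an amine or a carboxylic acid on this aromatic carbon would rest on the same limit or give a number.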